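Cyclopropyl in Place of Propyl: Expected Gain for Compound 4

This account rests on a few compounds, and the source may have more. Where it says the series, first, only, none or still open, it means among the compounds named here.

Compound 1 `CCCC(=O)N1CCC(c2cc(Cl)ccc2N)=N1` was tested in an assay on isolated protein for inhibition of Nitric oxide synthase, inducible (Homo sapiens), with a stated time of 30 min, tested at 1 mM (a lower number here means less inhibition, a higher number more inhibition at the concentration tested (going by the name of the read-out)), and gives 0.29%. Compound 2 `Nc1ccc(Cl)cc1C1=NN(C(=O)C2CC2)CC1` differs from it by cyclopropyl in place of propyl on a carbonyl carbon and gives 18.9% in this assay, a step of a number 18.6 percentage points higher from compound 1 to compound 2 (beyond the scatter). Compound 3 `CCCC(=O)N1CCC(c2ccccc2N)=N1` differs from compound 1 by hydrogen in place of chloro on an aromatic carbon; in this assay compound 3 gives 0.35%, which amounts to a number 0.1 percentage points higher from compound 1 to compound 3 (within the scatter). Compound 4 `Nc1ccccc1C1=NN(C(=O)C2CC2)CC1` has not yet been measured; it differs from compound 3 by cyclopropyl in place of propyl on a carbonyl carbon, the same change as that from compound 1 to compound 2. Within the data shown here, since the two cores differ in a way that hardly moved the number, and there is only one earlier instance of the change, compound 4 is expected to rise by a number 16.7 percentage points higher from compound 3 to compound 4 (beyond the scatter). Compound 4 is therefore estimated at 17% in this assay, with a likely range from 3% to 32%.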

Compound 4, a percentage reported as inhibition, at one concentration (the size of the read-out at that concentration, not a potency): 14.8%
Compound 4: middle estimate off by 2.2 percentage points, on the high side, within the range that was stated.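

In this assay, cyclopropyl in place of propyl on a carbonyl carbon again gives a clear rise, a number 14.5 percentage points higher from compound 3 to compound 4 (beyond the scatter), and the step is of like size on the two cores: the same change on two cores in this assay, a number 18.6 percentage points higher (beyond the scatter) from compound 1 to compound 2 and a number 14.5 percentage points higher (beyond the scatter) from compound 3 to compound 4, 4.2 percentage points apart, within the scatter of two such steps. Hydrogen in place of chloro stays within the scatter with cyclopropyl as well, at a number 4.1 percentage points lower from compound 2 to compound 4 (within the scatter): the same change on two cores in this assay, a number 0.1 percentage points higher (within the scatter) from compound 1 to compound 3 and a number 4.1 percentage points lower (within the scatter) from compound 2 to compound 4, 4.2 percentage points apart, within the scatter of two such steps. This supports carrying the change between these two cores only, as a read-out at one concentration; it does not show that the gain would hold on any other core, and it gives no potency.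

The compounds shown leave open whether a longer chain such as butyl, or a cyclobutyl group, on the carbonyl carbon would keep the gain. They also leave open what a fluoro or methoxy group in place of the chloro would do.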